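Cyclopropyl in place of allyl on the amide nitrogen

The source may report more compounds than this note shows. Statements on the series, on what has been measured and on what is new or still open speak of the compounds shown alone.

Three compounds have been measured in a toxicity assay on the whole organism (strain Icem-CET (SPF Caw)) for cytotoxicity, with Mus musculus as the target; a higher number here means that more compound is needed for the effect, a lower number that less compound is needed:

Compound 1, `C/C(C(=O)NC1CC1)=C(\C)c1ccc(C)cc1`, gives 500 mg/kg.
Compound 2, `C#CCNC(=O)/C(C)=C(\C)c1ccc(C)cc1`, gives 200 mg/kg.
Compound 3, `C=CCNC(=O)/C(C)=C(\C)c1ccc(C)cc1`, gives 170 mg/kg.

Compound 3 has the lowest number of the three. Compound 2 sits within the usual scatter of it, while compound 1 lies beyond it with the higher number. The new compound 4, `C/C(C(=O)NC1CC1)=C(/C)c1ccc(C)cc1`, differs from compound 3 in one spot: cyclopropyl in place of allyl on an amide-type nitrogen.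

For the measured compounds named here, only one measured step bears on this change, and only loosely: a 1.2-fold lower number from compound 2 to compound 3 (0.07 log units; within the scatter), a swap of one small unsaturated chain for another that stayed within the scatter. Going by the values given here, no measured step exchanges a chain for a ring on this nitrogen. Compound 4 differs only in the geometry of its double bond from compound 1, which carries the same cyclopropyl group on the same nitrogen and gives 500 mg/kg. Because compound 1 gives 500 mg/kg, compound 4 is expected to move toward a higher number, a 2.2-fold higher number from compound 3 to compound 4 (0.35 log units; beyond the scatter), though the geometry difference leaves this uncertain. The estimate for compound 4 is 380 mg/kg, between 190 mg/kg and 750 mg/kg.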

Compound 4, dose for half-maximal effect: 300 mg/kg
The estimate for compound 4 lay 1.3-fold (0.10 log units) above the measured number; measured number inside the range.
By their numbers in this assay, from the lowest: compounds 3, 2, 4 and 1 (each within the scatter of the next, the first and the last beyond it).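

In this assay, a ring in place of an open chain on the amide-type nitrogen gives a 1.8-fold higher number from compound 3 to compound 4 (0.25 log units; within the scatter), and the comparison with the propargyl chain gives a 1.5-fold higher number from compound 2 to compound 4 (0.18 log units; within the scatter), so allyl, propargyl and cyclopropyl cannot be told apart here. The geometry of the double bond cannot be read as mattering either, with a 1.7-fold lower number from compound 1 to compound 4 (0.22 log units; within the scatter). Compound 4 thus separates the two changes that lie between compound 1 and compound 3, and neither change alone goes beyond the scatter, a reading that rests on one point: the fact that compounds 1 and 4 differ only in the configuration as drawn

On these data alone, whether any group on this nitrogen can shift the number beyond the scatter remains open, for instance a longer chain such as hexyl, a cyclohexyl ring or a chain ending in an amine. The compounds shown also leave open why the number changes at all.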